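Aminophenyl for difluorophenyl on the ethenyl chain

A few compounds are considered here, and "the series" means these few. Any claim that something is new, unique, unknown or untested is made for them only; others in the source may bear on it.

Compound 2 `COc1ccc(C(=O)c2cc(OC)c(OC)c(OC)c2)cc1NC(=O)/C=C/c1ccc(F)c(F)c1` is one of two members of this series measured in a functional assay on COLO 205 cells (Homo sapiens) for cytotoxicity, read by MTT assay, with a stated time of 72 h (a lower number here means a stronger inhibitor, a higher number a weaker inhibitor), where compound 2 gives 6020 nM. Its companion compound 1 `COc1cccc(/C=C/C(=O)Nc2cc(C(=O)c3cc(OC)c(OC)c(OC)c3)ccc2OC)c1` gives 5100 nM in this assay; the two numbers lie within the scatter of each other, so neither can be ranked against the other. Going by the values given here, the single measured step, a 1.2-fold higher number from compound 1 to compound 2 (0.07 log units; within the scatter), exchanges the aryl group on the double-bonded chain carbon and moves nothing beyond the scatter.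

Compound 3 `COc1ccc(C(=O)c2cc(OC)c(OC)c(OC)c2)cc1NC(=O)/C=C/c1ccc(N)cc1` is the next member, not yet measured. Against compound 2 the change is 4-aminophenyl in place of 3,4-difluorophenyl on a double-bonded chain carbon bound to a double-bonded chain carbon. Among the compounds with values here, no measured step involves the 4-aminophenyl group; the only step at the same place, a 1.2-fold higher number from compound 1 to compound 2 (0.07 log units; within the scatter), was flat, so a further aryl swap there is expected to shift little, a 1.2-fold lower number from compound 2 to compound 3 (0.08 log units; within the scatter), not beyond the scatter. Compound 3 is therefore expected to give about 5000 nM in this assay, within a range of 2000 nM to 15000 nM.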

Compound 3, half-maximal inhibitory concentration: 10300 nM
Compound 3: the middle estimate sits 2.1-fold (0.31 log units) below what was measured; the range from low to high includes it.
By their numbers in this assay, from the lowest: compounds 1, 2 and 3 (each within the scatter of the next, the first and the last beyond it).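

The aryl group on a double-bonded chain carbon bound to a double-bonded chain carbon now yields a step beyond the scatter in this assay: the swap of 3-methoxyphenyl for 4-aminophenyl gives a 2.0-fold higher number from compound 1 to compound 3 (0.31 log units; beyond the scatter) and counts as modest. The swap of 3,4-difluorophenyl for 4-aminophenyl gives a 1.7-fold higher number from compound 2 to compound 3 (0.23 log units; within the scatter) and does not separate those two compounds. This place is therefore not flat for every aryl change, but the only separation shown is between compound 1 and compound 3.

No measurement on hand explains the difference between these aryl groups.

Still open, from the compounds shown here alone, is how a 4-hydroxyphenyl or 4-dimethylaminophenyl group would read at this place. Also open, going by these compounds, is whether a saturated ethyl chain in place of the ethenyl chain would shift the number in this assay by more than these aryl swaps do.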